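This account rests on a few compounds, and the source may have more. Where it says the series, first, only, none or still open, it means among the compounds named here.

Of the compounds shown here, three built on one shared core have been measured in an assay on HEK293 cells for positive allosteric modulation of metabotropic glutamate receptor 2 (Rattus norvegicus), read by thallium flux, with a stated time of 2.5 min; on this read-out lower numbers stand for an effect already at smaller amounts and higher numbers for an effect only at larger amounts of compound. Compound 1 `Cc1cc(C(=O)O)ccc1OCCCCOc1ccc(C(=O)CC(C)C)c(O)c1C` gives 192 nM. Compound 2 `Cc1c(OCCCCOc2ccc(C(=O)O)cc2)ccc(C(=O)CC(C)C)c1O` gives 122 nM, and compound 3 `Cc1cc(OCCCCOc2ccc(C(=O)CC(C)C)c(O)c2C)ccc1C(=O)O` gives 173 nM. Compound 1 has the highest of the three numbers, but the spread is narrow: a 1.6-fold lower number from compound 1 to compound 2 (0.20 log units; within the scatter), a 1.1-fold lower number from compound 1 to compound 3 (0.05 log units; within the scatter), and a 1.4-fold higher number from compound 2 to compound 3 (0.15 log units; within the scatter), so none of the three can be set apart from the others.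

Compound 4 `CC(=O)c1ccc(OCCCCOc2ccc(C(=O)O)cc2C)c(C)c1O` has not yet been measured. It differs from compound 1 in a single place: hydrogen in place of isopropyl on a saturated chain carbon bound to a carbonyl carbon. Within the data shown here, all three measured steps concern a methyl on an aromatic carbon or the arrangement of carboxy and methyl on the phenyl; none touches the chain bound to the carbonyl carbon, so no measured step bears directly on this change. What the measured steps do show is that small edits elsewhere on this core leave the number within the scatter. The present change is larger than any of those, so a shift beyond the scatter is plausible, and the loss of a group is taken here as more likely to move the number up than down. Compound 4 is therefore expected to give 450 nM in this assay, with a range from 120 nM to 1800 nM. The expected step is a 2.3-fold higher number from compound 1 to compound 4 (0.37 log units; beyond the scatter).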

Compound 4, half-maximal effective concentration: 50 nM
Beside the measured number, compound 4's estimate is 9.0-fold (0.95 log units) above it, outside the stated range (below it).
By their numbers in this assay, from the lowest: compound 4; then compounds 2, 3 and 1 (each within the scatter of the next).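

In this assay, among these compounds, the chain bound to the carbonyl carbon turns out to be a place where the number responds: trading isopropyl for hydrogen, which shortens isobutyl to methyl, gives a 3.8-fold lower number from compound 1 to compound 4 (0.58 log units; beyond the scatter) and is the first step on this core to clear the scatter, whereas the steps among the earlier compounds, which concerned a methyl on an aromatic carbon or the arrangement of carboxy and methyl on the phenyl, all stayed within it. It also shows that the isopropyl is not needed for the effect in this assay, since the acetyl compound, with the smaller group, acts at lower amounts than the isobutylcarbonyl compound. Nothing given here explains why the number falls with this change.

With only isobutyl and methyl compared at this place, the compounds shown leave open how the number would run through an ethyl group or a longer chain, and what an amine or a carboxylic acid on that chain would do. They also leave open whether the same change would lower the number when made on compound 2 or compound 3.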